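The compounds below may be only part of what the source reports. "The series", "measured", "known", "first", "only" and "open" are said of these compounds alone.

In a functional assay on HeLa cells (Homo sapiens) for antiproliferative activity, read by CCK-8 assay, with a stated time of 72 h; on this read-out higher numbers stand for weaker inhibition and lower numbers for stronger inhibition:

- Compound 1 `CCOc1ccc(-c2cncnc2-c2cc(OC)c(OC)c(OC)c2)cc1`: 250 nM
- Compound 2 `COc1cc(-c2ncncc2-c2ccc(C(N)=O)cc2)cc(OC)c1OC`: > 100000 nM (a limit, not a number)

From the compounds shown here alone, compound 2 has only a limit, > 100000 nM, so its true position is unknown. Compound 3 `CNC(=O)c1ccc(-c2cncnc2-c2cc(OC)c(OC)c(OC)c2)cc1` differs from compound 2 by methyl in place of hydrogen on an amide-type nitrogen, turning carbamoyl into methylcarbamoyl. Among the compounds with values here, the only measured step that bears on this is an at least 400-fold higher number from compound 1 to compound 2 (2.60 log units; beyond the scatter), a large step that brought in carbamoyl in place of ethoxy on an aromatic carbon. Within the data shown here, no measured step tests a change on the amide-type nitrogen itself. Compound 3 keeps the amide-type group introduced in that step of an at least 400-fold higher number from compound 1 to compound 2 (2.60 log units; beyond the scatter), so it is expected to remain far weaker than compound 1 at 250 nM, with a modest move towards lower numbers in this assay. The estimated step is an at least 3.3-fold lower number from compound 2 to compound 3 (0.52 log units; beyond the scatter). Compound 3 is expected at 30000 nM, with an estimated range of 3000 nM to 100000 nM.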

Compound 3, half-maximal inhibitory concentration: 1470 nM
Beside the measured number, compound 3's estimate is 20-fold (1.31 log units) above it; the whole stated range lies above it.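

In this assay, the amide-type nitrogen turns out to be a place where a single methyl matters: methyl in place of hydrogen there gives an at least 68-fold lower number from compound 2 to compound 3 (1.83 log units; beyond the scatter). The earlier pair showed only that carbamoyl in place of ethoxy costs a great deal, whereas methylcarbamoyl in place of ethoxy gives a 5.9-fold higher number from compound 1 to compound 3 (0.77 log units; beyond the scatter), so an amide-type group on that aromatic carbon does not by itself carry the whole loss seen with compound 2. Compound 2 is held only by a limit of the assay, so the step from it has a floor and no fixed size: the limit of > 100000 nM in this assay, at which 1 of the 3 values shown sits.

From the compounds shown here alone, whether ethyl on that nitrogen, or a second methyl giving dimethylcarbamoyl, would move the number further remains open. The compounds shown also leave open how a carboxylic acid or an amine on that aromatic carbon would read.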